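The source may report more compounds than this note shows. Statements on the series, on what has been measured and on what is new or still open speak of the compounds shown alone.

Measured compounds:
- compound 1 `COc1cccc(/C=C/C(=O)c2sc(Nc3ccccc3)nc2C)c1`, in a functional assay on PC-3 cells (Homo sapiens) for cytotoxicity, read by MTT assay (on this read-out lower numbers stand for stronger inhibition and higher numbers for weaker inhibition), compound 1 gives > 25000 nM, which is a limit of the assay and not a number.
- compound 2 `Cc1nc(Nc2ccc(Cl)c(Cl)c2)sc1C(=O)/C=C/c1ccccc1`, in this assay compound 2 gives 7990 nM.
- compound 3 `Cc1nc(Nc2ccc(Cl)c(Cl)c2)sc1C(=O)/C=C/c1ccc(Cl)cc1`, in this assay compound 3 gives > 25000 nM, again a limit of the assay.

Among the compounds with values here, compound 2 is thus the only compound of the three with a measured number; the other two sit at the limit, as the limit of > 25000 nM in this assay, at which 2 of the 3 values shown sit, shows. Compound 4 `Cc1ccc(Nc2nc(C)c(C(=O)/C=C/c3ccccc3)s2)cc1` differs from compound 2 by 4-methylphenyl in place of 3,4-dichlorophenyl on a nitrogen on an aromatic ring. Within the data shown here, no measured step changes this part of the molecule; the only measured step, an at least 3.1-fold higher number from compound 2 to compound 3 (0.49 log units; beyond the scatter), concerns the other ring. Among the measured compounds shown here, with two of three compounds at the limit and no step bearing directly on the amine-side change, a weakening is expected: compound 4 is estimated at 15000 nM (range 5000 nM to 40000 nM), a step of a 1.9-fold higher number from compound 2 to compound 4 (0.27 log units; within the scatter).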

Compound 4, half-maximal inhibitory concentration: > 25000 nM
Compound 4 ended at the assay's limit (the forecaster's own chance of this, stated with the estimate: 50%); middle value at least 1.6-fold (0.22 log units) away from the limit.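

In this assay, 4-methylphenyl in place of 3,4-dichlorophenyl on the nitrogen gives an at least 3.1-fold higher number from compound 2 to compound 4 (0.49 log units; beyond the scatter), the first step read at this position. Compound 4 sits at a limit of the assay, so this step gives only a smallest size. A measurable number at this position is thus not kept on this change, and the limit now holds most of the compounds: the limit of > 25000 nM in this assay, at which 3 of the 4 values shown sit.

Open, from the compounds shown here alone, is how far the true value of compound 4 lies from that of compound 2. Also open, going by these compounds, is whether a phenyl ring carrying a nitrile or a carboxylic acid on this nitrogen would give a number.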